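The source may hold more compounds than are shown below. What is called first, only, known or untested is meant among the compounds shown, and "the series" means these compounds.

Measured compounds in a functional assay on KB-VIN10 cells (Homo sapiens) for inhibition, with a stated time of 72 h; on this read-out lower numbers stand for stronger inhibition and higher numbers for weaker inhibition:
compound 1 `COc1ccc(S(=O)(=O)N2CCc3cccc(-c4ccc(F)cc4)c32)cc1` gives 94.6 nM
compound 2 `COc1ccc(S(=O)(=O)N2CCc3cccc(-c4ccc(N(C)C)cc4)c32)cc1` gives 553 nM
compound 3 `COc1ccc(-c2cccc3c2N(S(=O)(=O)c2ccc(OC)cc2)CC3)cc1` gives 352 nM

Compound 3 holds the second highest number of the three: it sits close to compound 2, a gap within the scatter, and clearly above compound 1, a gap beyond it. The step to compound 4 `COc1ccc(S(=O)(=O)N2CCc3cccc(-c4cccs4)c32)cc1` is thiophen-2-yl in place of 4-methoxyphenyl on an aromatic carbon. Within the data shown here, no measured step alters this ring itself; the three measured steps all exchange the group carried on the phenyl. Fluoro gave the lowest number, with a 3.7-fold higher number from compound 1 to compound 3 (0.57 log units; beyond the scatter) and a 5.8-fold higher number from compound 1 to compound 2 (0.77 log units; beyond the scatter) both moving upward, while a 1.6-fold lower number from compound 2 to compound 3 (0.20 log units; within the scatter) stayed within the scatter. The ring exchange in compound 4 is thus not covered by any measured step; the data only show that exchanges at this aromatic carbon shift the number by modest amounts in both directions. Without a direct guide, a modest lowering toward compound 1 is expected, a 2.2-fold lower number from compound 3 to compound 4 (0.34 log units; beyond the scatter), with wide uncertainty. Compound 4 is estimated at 160 nM, range 50 nM to 500 nM.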

Compound 4, half-maximal inhibitory concentration: 251 nM
Beside the measured number, compound 4's estimate is 1.6-fold (0.20 log units) below it, and the stated range covers the measured number.
By their numbers in this assay, from the lowest: compound 1; then compounds 4, 3 and 2 (each within the scatter of the next, the first and the last beyond it).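

In this assay, replacing the phenyl ring itself at this aromatic carbon gives a 1.4-fold lower number from compound 3 to compound 4 (0.15 log units; within the scatter), so thiophen-2-yl and 4-methoxyphenyl cannot be told apart here. The same ring exchange reads differently against the other two phenyl groups, with a 2.2-fold lower number from compound 2 to compound 4 (0.34 log units; beyond the scatter) and a 2.7-fold higher number from compound 1 to compound 4 (0.42 log units; beyond the scatter), which places thiophen-2-yl within the span of the phenyl compounds and leaves compound 1, with its 4-fluorophenyl group, holding the lowest number of the four. No evidence is available to explain these differences.

Still open, going by these compounds, is whether a different ring at this carbon, such as thiophen-3-yl, a pyridine or an unsubstituted phenyl, would reach the level of compound 1. On these data alone, it is also open whether a fluoro group on the thiophene ring would lower the number as it does on the phenyl series.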